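Adding a pyrazolyl group to compound 2

A few compounds are considered here, and "the series" means these few. Any claim that something is new, unique, unknown or untested is made for them only; others in the source may bear on it.

Of the compounds shown here, two have been measured in a functional assay on HCT-116 cells (Homo sapiens) for inhibition, read by MTT assay, with a stated time of 72 h; a lower number here means a stronger inhibitor of growth, a higher number a weaker inhibitor of growth. Within the data shown here, compound 1 (`Cc1cc(CN2CCN(c3c(Br)cnc4[nH]c(N5CCN(Cn6cccn6)CC5)nc34)CC2)no1`) gives 120 nM and compound 2 (`Cc1cc(CN2CCN(c3c(Cl)cnc4[nH]c(N5CCN(C)CC5)nc34)CC2)no1`) gives 140 nM, so compound 2 stands within the scatter of its only neighbour. Compound 3 (`Cc1cc(CN2CCN(c3c(Cl)cnc4[nH]c(N5CCN(Cn6cccn6)CC5)nc34)CC2)no1`) follows from compound 2 through (1H-pyrazol-1-yl in place of hydrogen on a saturated chain carbon bound to an amine nitrogen in a ring), with 1H-pyrazol-1-yl in place of hydrogen on a saturated chain carbon bound to an amine nitrogen in a ring. Compound 1 also carries this group and gives 120 nM, so no change beyond the scatter is expected in this assay. The expected step is a 1.1-fold lower number from compound 2 to compound 3 (0.03 log units; within the scatter). For compound 3 the estimated value is 130 nM, with an expected range of 60 nM to 280 nM.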

Compound 3, concentration for 50% growth inhibition: 450 nM
Compound 3: middle estimate off by 3.5-fold (0.54 log units), on the low side; measured number above the stated range.
By their numbers in this assay, from the lowest: compounds 1 and 2 (each within the scatter of the next); then compound 3.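

In this assay the change from methyl to (1H-pyrazol-1-yl)methyl is not neutral with chloro on the aromatic carbon, giving a 3.2-fold higher number from compound 2 to compound 3 (0.51 log units; beyond the scatter) in the chloro compounds. With that group held fixed, the halogen also counts: chloro in place of bromo gives a 3.8-fold higher number from compound 1 to compound 3 (0.57 log units; beyond the scatter) and this could not be read before, since compound 1 and compound 2 differ in two places. Nothing measured here explains either step. The compounds shown leave open whether the pyrazolyl group has the same effect with bromo, since none pairs bromo with methyl. They also leave open how iodo on that aromatic carbon, or an ethyl group in place of methyl, would read.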